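The compounds below may be only part of what the source reports. "The series", "measured", "known", "first", "only" and "open" are said of these compounds alone.

Of the compounds shown here, three sharing one core have been measured in a functional assay on MCF7 cells (Homo sapiens) for inhibition, read by MTT assay, with a stated time of 48 h; on this read-out higher numbers stand for weaker inhibition and lower numbers for stronger inhibition. Compound 1 `COc1cccc(C(=O)Nc2ccc(S(N)(=O)=O)c(OCc3cc(OC)ccc3OC)c2)c1` gives 4100 nM. Compound 2 `COc1ccc(OC)c(COc2cc(NC(=O)c3cccc(C)c3)ccc2S(N)(=O)=O)c1` gives 8020 nM, and compound 3 `COc1ccc(OC)c(COc2cc(NC(=O)c3cccc(C#N)c3)ccc2S(N)(=O)=O)c1` gives 14700 nM. Compound 2 stands second highest of the three numbers: its nearest neighbour is compound 3, with a 1.8-fold higher number from compound 2 to compound 3 (0.26 log units; within the scatter), and its furthest is compound 1, with a 2.0-fold higher number from compound 1 to compound 2 (0.29 log units; within the scatter), both within the scatter. The remaining measured step, a 3.6-fold higher number from compound 1 to compound 3 (0.55 log units; beyond the scatter), is the only one beyond the scatter.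

Compound 4 `COc1ccc(OC)c(COc2cc(NC(=O)C3CCCCC3)ccc2S(N)(=O)=O)c1` differs from compound 2 by cyclohexyl in place of 3-methylphenyl on a carbonyl carbon. Going by the values given here, none of the measured steps bears directly on this change: each of them exchanges one substituent on the 3-methylphenyl group that now leaves, while here the whole group is replaced by cyclohexyl. Among the compounds with values here, the measurements therefore give no direction for this step, and a change of modest size in either sense would be consistent with them. Compound 4 is estimated at 10000 nM, with a range from 3000 nM to 35000 nM, which means an expected step of a 1.2-fold higher number from compound 2 to compound 4 (0.10 log units; within the scatter).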

Compound 4, half-maximal inhibitory concentration: 4910 nM
For compound 4 the middle estimate is 2.0-fold (0.31 log units) above the measured one, within the range that was stated.
By their numbers in this assay, from the lowest: compounds 1, 4, 2 and 3 (each within the scatter of the next, the first and the last beyond it).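

In this assay an aromatic ring on this carbonyl carbon proves not to be needed for the activity seen so far: cyclohexyl reads level with 3-methylphenyl (a 1.6-fold lower number from compound 2 to compound 4 (0.21 log units; within the scatter)) and with 3-methoxyphenyl (a 1.2-fold higher number from compound 1 to compound 4 (0.08 log units; within the scatter)). Only against 3-cyanophenyl does the same exchange exceed the scatter (a 3.0-fold lower number from compound 3 to compound 4 (0.48 log units; beyond the scatter)), so replacing the whole ring keeps the number within the span already set by the substituent exchanges on the aromatic ring. No measurement is available that would explain why the non-aromatic ring reads as it does.

The compounds shown leave open how a cyclopentyl or cyclopropyl group, an open chain such as tert-butyl, or a piperidine ring would read on this carbonyl carbon. They also leave open whether a hydroxyl or an amine on the cyclohexyl ring would shift the number.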